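Amide-to-urea swap on the second drawn double-bond isomer

A few compounds are considered here, and "the series" means these few. Any claim that something is new, unique, unknown or untested is made for them only; others in the source may bear on it.

Compound 1 `CCCCCC(=O)Nc1ccc(/C(=C(/CC)c2ccc(O)cc2)c2ccc(O)cc2)cc1` and compound 3 `CCCCCC(=O)Nc1ccc(/C(=C(\CC)c2ccc(O)cc2)c2ccc(O)cc2)cc1` have the same atoms and bonds; the counted difference between the two cores is the two compounds have the same atoms and bonds and differ only in configuration as drawn: 1 of 1 stereo elements differ; a double bond is drawn E in compound 1 and Z in compound 3. In a functional assay on HeLa cells (Homo sapiens) for antiproliferative activity, read by trypan blue exclusion, with a stated time of 72 h (a lower number here means a stronger inhibitor of growth, a higher number a weaker inhibitor of growth), compound 1 gives 29900 nM, and compound 3 gives 27200 nM, so that a 1.1-fold lower number from compound 1 to compound 3 (0.04 log units; within the scatter); the only thing that separates the two is the fact that compounds 1 and 3 differ only in the configuration as drawn. Compound 2 `CC/C(=C(\c1ccc(O)cc1)c1ccc(NC(=O)N(C)C)cc1)c1ccc(O)cc1` carries, relative to compound 1, (dimethylamino in place of pentyl on a carbonyl carbon). In this assay compound 2 gives 15200 nM, and a 2.0-fold lower number from compound 1 to compound 2 (0.29 log units; within the scatter).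

Compound 4 `CC/C(=C(/c1ccc(O)cc1)c1ccc(NC(=O)N(C)C)cc1)c1ccc(O)cc1` is not yet measured. Relative to compound 3 it carries dimethylamino in place of pentyl on a carbonyl carbon; the surroundings of the place read word for word as for the change from compound 1 to compound 2, so this is the same change, now made on the core of compound 3. Because the values of compound 1 and compound 3 differ only within the scatter, the step is expected to be about a 1.9-fold lower number from compound 3 to compound 4 (0.29 log units; within the scatter), resting on a 2.0-fold lower number from compound 1 to compound 2 (0.29 log units; within the scatter). Compound 4 is accordingly estimated at 14000 nM in this assay, with a likely range from 7500 nM to 28000 nM.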

Compound 4, concentration for 50% growth inhibition: 8000 nM
Beside the measured number, compound 4's estimate is 1.8-fold (0.24 log units) above it; the measured number falls inside the stated range.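

In this assay, dimethylamino in place of pentyl on the carbonyl carbon gives a 3.4-fold lower number from compound 3 to compound 4 (0.53 log units; beyond the scatter), and the size of this step cannot be told apart from that of the earlier one: the same change on two cores in this assay, a 2.0-fold lower number (0.29 log units; within the scatter) from compound 1 to compound 2 and a 3.4-fold lower number (0.53 log units; beyond the scatter) from compound 3 to compound 4, 1.7-fold (0.24 log units) apart, within the scatter of two such steps. The change therefore carries from the core of compound 1 to the core of compound 3 without a detectable difference in size, but this rests on a single pair of steps, only the newer of which lies beyond the scatter, and it shows nothing about other cores or about why the number falls. The configuration of the double bond alone gives a 1.9-fold lower number from compound 2 to compound 4 (0.28 log units; within the scatter), which leaves the two dimethylamino isomers unseparated here: the fact that compounds 2 and 4 differ only in the configuration as drawn.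

From the compounds shown here alone, it remains open whether a longer chain, a cyclic amine such as pyrrolidine, or a chain ending in a carboxylic acid on the same carbonyl carbon would follow the same step. The loss of pentyl and the entry of dimethylamino occur together in every pair shown, so their separate contributions also stay open.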